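Adding a Methyl to the Benzyl Ether of Compound 3

This account rests on a few compounds, and the source may have more. Where it says the series, first, only, none or still open, it means among the compounds named here.

Three compounds sharing a core were tested in a functional assay on DU-145 cells (Homo sapiens) for antiproliferative activity, read by sulforhodamine B assay, with a stated time of 72 h; on this read-out higher numbers stand for weaker inhibition of growth and lower numbers for stronger inhibition of growth. Compound 1 `CCc1cc(=O)c2ccc(Sc3cccc(Cl)[n+]3[O-])cc2o1` gives a limit of the assay rather than a number, > 29900 nM. Compound 2 `CCc1cc(=O)c2ccc(Sc3cccc(Cl)[n+]3[O-])c(C)c2o1` likewise gives only a limit, > 28700 nM. The change from compound 1 to compound 2 is methyl in place of hydrogen on an aromatic carbon, and its size is a step that the two limits leave unreadable from compound 1 to compound 2. Within the data shown here, compound 3 `CCc1cc(=O)c2ccc(OCc3ccccc3)c(C)c2o1` gives the only number, 27700 nM. How the core of compound 3 differs from that of compound 1 is not broken down here. Compound 4 `CCc1cc(=O)c2ccc(OCc3cccc(C)c3)c(C)c2o1` has not been measured; it differs from compound 3 by methyl in place of hydrogen on an aromatic carbon, the same kind of change as from compound 1 to compound 2, though here the methyl sits meta to a large group rather than ortho to a fused ring. The earlier step has no readable size, so the expectation rests on compound 3 alone with 27700 nM. Compound 4 is expected to give 25000 nM, between 8000 nM and 60000 nM. The expected step is a 1.1-fold lower number from compound 3 to compound 4 (0.04 log units; within the scatter), within the usual scatter.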

Compound 4, concentration for 50% growth inhibition: 24100 nM
For compound 4 the middle estimate is 1.0-fold (0.02 log units) above the measured one; the range from low to high includes it.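

In this assay, replacing phenyl with 3-methylphenyl gives a 1.1-fold lower number from compound 3 to compound 4 (0.06 log units; within the scatter), so on this core the added methyl cannot be told apart from the usual variation between repeat measurements. The same kind of change on the other core, from compound 1 to compound 2, cannot be read: each of those two compounds gives only a limit of the assay. The series therefore does not show whether a methyl behaves alike on the two cores, and the two methyls also sit at different places.

Still open, from the compounds shown here alone, is whether a different group at the same place, such as an amine, a carboxylic acid or a longer chain, would give a step beyond the scatter.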